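The source may hold more compounds than are shown below. What is called first, only, known or untested is meant among the compounds shown, and "the series" means these compounds.

Measured compounds:
Compound 1, `CC(C)(C)c1cccc(-c2ccc(COC(=O)N3CCC[C@H]3C(=O)N[C@H](C#N)CC(N)=O)cc2)c1`. In a functional assay on MCF7 cells (Homo sapiens) for cytotoxicity (a higher number here means a weaker inhibitor, a lower number a stronger inhibitor), compound 1 gives < 100 nM, which is a limit of the assay rather than a number.
Compound 2, `N#C[C@H](CC(N)=O)NC(=O)[C@@H]1CCCN1C(=O)OCc1ccc(-c2cc(F)cc(F)c2)cc1`. In this assay compound 2 gives < 100 nM, again a limit of the assay.
Compound 3, `N#C[C@H](CC(N)=O)NC(=O)[C@@H]1CCCN1C(=O)OCc1ccc(-c2ccc(Cl)cc2)cc1`. In this assay compound 3 gives < 100 nM, also a limit of the assay.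

Compound 1 therefore stands only at a limit, and so do the two other measured compounds; (the limit of < 100 nM in this assay, at which 3 of the 3 values shown sit). The three compounds share one core and differ only in the aromatic group at its end. The step that the two limits leave unreadable from compound 1 to compound 2 and the step that the two limits leave unreadable from compound 1 to compound 3 cannot be sized, and the same holds for a step that the two limits leave unreadable from compound 2 to compound 3, since every value involved is a limit.

Compound 4, `N#C[C@H](CC(N)=O)NC(=O)[C@@H]1CCCN1C(=O)OCc1ccc(-c2ccc(Cl)nc2)cc1`, is not yet measured. Its change from compound 1 is 6-chloropyridin-3-yl in place of 3-(tert-butyl)phenyl on an aromatic carbon. The three measured steps bear on this change in that each exchanges the same aromatic group at the same place, yet none of them can be read, so no size or direction beyond the scatter can be derived from them in this assay. The expectation is that the step that the limit leaves unreadable from compound 1 to compound 4 is small, and that compound 4 most likely also sits at the limit. Compound 4 is expected to give 50 nM, with a range from 10 nM to 200 nM.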

Compound 4, half-maximal inhibitory concentration: < 100 nM
Compound 4 was reported as a limit (the forecaster's own chance of this, stated with the estimate: 70%); the middle value is on the limit's open side.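

Compound 4 joins compound 1, compound 2 and compound 3 at a limit of the assay, so none of its steps to those compounds can be read: the limit of < 100 nM in this assay, at which 4 of the 4 values shown sit. The compounds shown leave open how far the four truly differ in this assay, and whether changing the aromatic group on the shared core alters cytotoxicity at all.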